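The compounds below may be only part of what the source reports. "The series", "measured", "known", "first", "only" and "open" are said of these compounds alone.

The series rests on a shared core, carried by three compounds already measured in a functional assay on MGC-803 cells (Homo sapiens) for antiproliferative activity, read by MTT assay, with a stated time of 72 h; a higher number here means a weaker inhibitor, a lower number a stronger inhibitor. Compound 1 `O=C1OCC[C@@H]1NC(=S)SCCOc1ccc([N+](=O)[O-])cc1` reaches only a limit of the assay there, > 100000 nM. Compound 3 `CCCCCCCCCCSC(=S)N[C@H]1CCOC1=O` likewise gives only a limit, > 64000 nM, in this assay. Among the compounds with values here, compound 2 `COc1ccccc1/C=C/C(=O)c1ccc(OCC(=O)N[C@H]2CCOC2=O)cc1` is the one member with a number: in this assay compound 2 gives 39400 nM. Compound 2 therefore stands alone among the values shown, while the other two sit at a limit, the limit of > 100000 nM in this assay, at which 1 of the 3 values shown sits, and (the limit of > 64000 nM in this assay, at which 1 of the 3 values shown sits).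

Compound 4 `O=C(COc1ccc(C(=O)/C=C/c2cccc(F)c2)cc1)N[C@H]1CCOC1=O` has not yet been measured. It differs from compound 2 in a single place: 3-fluorophenyl in place of 2-methoxyphenyl on a double-bonded chain carbon bound to a double-bonded chain carbon. Within the data shown here, no measured pair isolates this change, so there is no step to lean on, and the expectation is that the change stays within the scatter, in no set direction. On that basis it is expected that a 1.1-fold lower number from compound 2 to compound 4 (0.05 log units; within the scatter) amounts to nothing beyond the scatter in this assay. Compound 4 is accordingly estimated to give about 35000 nM in this assay, between 12000 nM and 100000 nM, with some chance that it too returns only a limit.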

Compound 4, half-maximal inhibitory concentration: > 64000 nM
Compound 4: only a limit was reported (the forecaster's own chance of this, stated with the estimate: 20%); middle value at least 1.8-fold (0.26 log units) from the limit.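

Within the data shown here, this is the first step at this place, on a double-bonded chain carbon bound to a double-bonded chain carbon, and in this assay the change from 2-methoxyphenyl to 3-fluorophenyl gives an at least 1.6-fold higher number from compound 2 to compound 4 (0.21 log units; that floor lies within the scatter). Compound 4 gives > 64000 nM, which is a limit of the assay and not a number. The change thus takes the series' only numbered compound to a limit, but because the floor of the step lies within the scatter, it establishes no real loss of activity, and compound 4 simply joins the values that rest on a limit: the limit of > 64000 nM in this assay, at which 2 of the 4 values shown sit.

As far as these compounds go, how far compound 4 lies past its limit remains unknown, so the true size of the step cannot be read, and the swap alters both the substituent and where it sits on the phenyl ring, leaving those two parts of the change unseparated. From the compounds shown here alone, whether an unsubstituted phenyl, a 2-fluorophenyl or a phenyl bearing a dimethylamino group on the same chain carbon would give a number in this assay also remains open.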